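The compounds below may be only part of what the source reports. "The series", "measured", "known", "first", "only" and "open" are said of these compounds alone.

Compound 2 `CC(C)(C)[C@H]1CC[C@H](N(Cc2ccc(C(=O)NCCC(=O)O)cc2)C(=O)Nc2cc(Cl)cc(Cl)c2)CC1` is the stronger of the two measured compounds in an in vitro assay on BHK cells for inhibition of Glucagon receptor (Homo sapiens) (on this read-out higher numbers stand for weaker inhibition and lower numbers for stronger inhibition), where compound 2 gives 80 nM. Going by the values given here, its only measured neighbour is compound 1 `CC(C)(C)[C@H]1CC[C@H](N(Cc2ccc(C(=O)NCCC(=O)O)cc2)C(=O)Nc2ccc(Cl)c(Cl)c2)CC1`, for which this assay gives 226 nM; the step between them, a 2.8-fold lower number from compound 1 to compound 2 (0.45 log units; beyond the scatter), concerns only the dichlorophenyl group on the amide-type nitrogen. Compound 3 `O=C(O)CCNC(=O)c1ccc(CN(C(=O)Nc2cc(Cl)cc(Cl)c2)c2ccc(C3=CCCCC3)cc2)cc1` keeps that group and changes another part: 4-(cyclohex-1-en-1-yl)phenyl in place of 4-(tert-butyl)cyclohexyl on an amide-type nitrogen. Among the compounds with values here, no measured step touches this position, so the one known step gives no guide to its direction or size. The change is large in shape, swapping a saturated ring with two defined stereocentres for an aromatic ring bearing a non-aromatic ring, so a wide range of outcomes is plausible. The step from compound 2 to compound 3 in this assay is therefore expected to be about a 2.0-fold higher number from compound 2 to compound 3 (0.30 log units; within the scatter). Compound 3 is estimated at 160 nM, with a range from 30 nM to 900 nM.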

Compound 3, half-maximal inhibitory concentration: 27 nM
Compound 3: the middle estimate sits 5.9-fold (0.77 log units) above what was measured; the whole stated range lies above it.
By their numbers in this assay, from the lowest: compound 3; then compound 2; then compound 1.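

The position on the amide-type nitrogen had not been probed by the earlier step between the two dichlorophenyl groups, and in this assay it proves open to a large change. Putting 4-(cyclohex-1-en-1-yl)phenyl in place of 4-(tert-butyl)cyclohexyl brings a 3.0-fold lower number from compound 2 to compound 3 (0.47 log units; beyond the scatter) and shows that stronger inhibition here does not depend on the saturated ring or its 2 defined stereocentres. The entering group, which has 12 carbon atoms and no hydrogen-bond donors or acceptors, adds an aromatic ring and a double bond together, so this single step cannot divide the gain between them.

Groups such as 4-(tert-butyl)phenyl or 4-cyclohexylphenyl on the same nitrogen would be needed to separate those two features. No measurement shown here bears on why the number falls at this position.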